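A few compounds are considered here, and "the series" means these few. Any claim that something is new, unique, unknown or untested is made for them only; others in the source may bear on it.

The read-out used here is a functional assay on HepG2 cells (Homo sapiens) for cytotoxicity, with a stated time of 72 h; on this read-out higher numbers stand for an effect only at larger amounts of compound and lower numbers for an effect already at smaller amounts. Compound 2, with the structure `C=C[C@@](C)(/C=C/c1ccc(Nc2ccccc2)cc1)CCC=C(C)C`, is the starting point. In this assay compound 2 gives > 52000 nM, which is a limit of the assay rather than a number. The two other measured compounds end the same way. Compound 1, `COc1ccc(/C=C/[C@@](C)(/C=C/c2ccc(O)cc2)CCC=C(C)C)cc1`, gives > 52000 nM, a limit. Compound 3, `C=C[C@@](C)(/C=C/c1ccc(Nc2cccc(OC(F)(F)F)c2)cc1)CCC=C(C)C`, gives > 52000 nM, again a limit. Within the data shown here, because of the limit of > 52000 nM in this assay, at which 3 of the 3 values shown sit, the only step that can be computed, a step that the two limits leave unreadable from compound 2 to compound 3, cannot be read as a size or a direction: both of its ends are limits.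

The new compound is compound 4, `C=C[C@@](C)(/C=C/c1ccc(Nc2c(F)cc(F)cc2F)cc1)CCC=C(C)C`. Its change from compound 2 is 2,4,6-trifluorophenyl in place of phenyl on a nitrogen on an aromatic ring.

Among the measured compounds shown here, the only step that bears on this change, the one from compound 2 to compound 3, is unreadable, so there is no measured size to lean on. What the three measured compounds share is that none of them shows an effect within the tested range. On that basis compound 4 is expected to behave the same way, and the expected step that the limit leaves unreadable from compound 2 to compound 4 is none that could be read beyond the scatter. The estimate for compound 4 is 80000 nM, within a range from 30000 nM to 250000 nM, most likely reported only as a limit.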

Compound 4, half-maximal effective concentration: > 52000 nM
Compound 4 was reported as a limit; the forecaster's own chance of this, stated with the estimate: 80%; the middle value does not contradict the limit.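

In this assay compound 4 gives > 52000 nM, which is a limit and not a number. No size or direction can be read for the change from compound 2 to compound 4, because both compounds sit at the same limit: the limit of > 52000 nM in this assay, at which 4 of the 4 values shown sit.

On these data alone, whether compound 1, compound 2, compound 3 and compound 4 truly differ in this assay stays open.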